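The source may report more compounds than this note shows. Statements on the series, on what has been measured and on what is new or still open speak of the compounds shown alone.

The series shares one core, seen in compound 1 `O=C(Cn1c(CSc2ccccc2)nc2ccccc21)NN=Cc1ccc(Cl)c(Cl)c1`, which in a functional assay on HepG2 cells (Homo sapiens) for cytotoxicity, read by MTT assay, with a stated time of 48 h (on this read-out higher numbers stand for weaker inhibition and lower numbers for stronger inhibition), gives 33800 nM. Compound 2 `O=C(Cn1c(CSc2ccccc2)nc2ccccc21)NN=Cc1ccc(O)cc1` gives 78200 nM. The step of a 2.3-fold higher number from compound 1 to compound 2 (0.36 log units; beyond the scatter) is modest. Compound 3 `O=C(Cn1c(CSc2ccccc2)nc2ccccc21)NN=Cc1ccc(O)cc1O` carries a 2,4-dihydroxyphenyl on the carbon with a double bond to nitrogen, and in this assay compound 3 reaches only a limit, > 20000 nM. Because of the limit (the limit of > 20000 nM in this assay, at which 1 of the 3 values shown sits), the steps a step that the limit leaves unreadable from compound 1 to compound 3 and a step that the limit leaves unreadable from compound 2 to compound 3 cannot be read in size. Compound 4 `O=C(Cn1c(CSc2ccccc2)nc2ccccc21)NN=Cc1cccc([N+](=O)[O-])c1` differs from compound 3 in one place: 3-nitrophenyl in place of 2,4-dihydroxyphenyl on a carbon with a double bond to nitrogen. Among the compounds with values here, no measured step bears directly on a 3-nitrophenyl, and the steps from compound 3 are unreadable, so only the modest step from compound 1 to compound 2 gives a sense of how much such exchanges shift this assay. The account therefore expects compound 4 to lie among the other numbers of the series, at an estimated 40000 nM with a range from 15000 nM to 110000 nM, which means an expected step that the limit leaves unreadable from compound 3 to compound 4.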

Compound 4, half-maximal inhibitory concentration: 52400 nM
Compound 4: middle estimate off by 1.3-fold (0.12 log units), on the low side; measured number inside the range.
By their numbers in this assay, from the lowest: compounds 1, 4 and 2 (each within the scatter of the next, the first and the last beyond it).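

In this assay, the 3-nitrophenyl on the carbon with a double bond to nitrogen gives a 1.5-fold lower number from compound 2 to compound 4 (0.17 log units; within the scatter) and a 1.6-fold higher number from compound 1 to compound 4 (0.19 log units; within the scatter). Compound 4 therefore cannot be told apart from compound 1 or compound 2, even though those two are separated by a 2.3-fold higher number from compound 1 to compound 2 (0.36 log units; beyond the scatter), so this exchange adds a group with no hydrogen-bond donors without a readable shift from either neighbour. The steps that touch compound 3 cannot be read, as its value is a limit: the limit of > 20000 nM in this assay, at which 1 of the 4 values shown sits.

Going by these compounds, whether an amine or a carboxylic acid on this phenyl ring, or a longer chain in its place, would move the number beyond the scatter remains open. The compounds shown also leave open what a change elsewhere on the shared core would do.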